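The source may report more compounds than this note shows. Statements on the series, on what has been measured and on what is new or still open speak of the compounds shown alone.

Compound 1 `NC1=NC2(CCOCC2)N(OCCCOc2cccc(Cl)c2Cl)C(N)=N1`: 330 nM
Compound 2 `NC1=NC2(CCOCC2)N(OCCCOc2ccc(Cl)c(Cl)c2)C(N)=N1`: 380 nM
Compound 3 `NC1=NC2(CCOCC2)N(OCCCOc2ccccc2Br)C(N)=N1`: 860 nM

All three values come from a functional assay on HepG2 cells (Homo sapiens) for antiproliferative activity, read by MTT assay, with a stated time of 72 h; a lower number here means a stronger inhibitor, a higher number a weaker inhibitor. Of these, compound 3 gives the highest number, 860 nM, making it the weakest inhibitor so far. Compound 4 `NC1=NC2(CCOCC2)N(OCCCOc2cccc(Cl)c2)C(N)=N1` has 3-chlorophenyl in place of 2-bromophenyl on an oxygen on a saturated carbon.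

The two dichlorophenyl groups cannot be told apart, with a 1.2-fold higher number from compound 1 to compound 2 (0.06 log units; within the scatter). Changing either one to 2-bromophenyl gave modest steps: a 2.6-fold higher number from compound 1 to compound 3 (0.42 log units; beyond the scatter) and a 2.3-fold higher number from compound 2 to compound 3 (0.35 log units; beyond the scatter). For the measured compounds named here, no measured step tests 3-chlorophenyl directly, so the evidence is indirect. In this assay, a small move towards a lower number is expected, probably within the scatter: a 1.4-fold lower number from compound 3 to compound 4 (0.16 log units; within the scatter). Compound 4 is estimated at 600 nM, with an expected range from 280 nM to 1300 nM.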

Compound 4, half-maximal inhibitory concentration: 150 nM
Compound 4: middle estimate off by 4.0-fold (0.60 log units), on the high side, and the stated range ends above it.
By their numbers in this assay, from the lowest: compound 4; then compounds 1 and 2 (each within the scatter of the next); then compound 3.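

In this assay, for the compounds shown here, 3-chlorophenyl in place of 2-bromophenyl gives the largest step so far, a 5.7-fold lower number from compound 3 to compound 4 (0.76 log units; beyond the scatter), and makes compound 4 the strongest inhibitor of the four. Hydrogen in place of chloro on an aromatic carbon also lowers the number, with a 2.5-fold lower number from compound 2 to compound 4 (0.40 log units; beyond the scatter) and a 2.2-fold lower number from compound 1 to compound 4 (0.34 log units; beyond the scatter), so a second chloro is not needed for a low number here. Nothing shown gives a reason for these steps.

The step from compound 3 changes both the halogen and where it sits, so these compounds cannot separate those two changes. On these data alone, whether any halogen is needed remains open, as plain phenyl or methoxyphenyl on the same oxygen would show.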